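Extending the amine of a benzisoxazole sulfonamide from ethyl to isopropyl

A few compounds are considered here, and "the series" means these few. Any claim that something is new, unique, unknown or untested is made for them only; others in the source may bear on it.

Of the compounds shown here, three of one series have been tested in a functional assay on the whole organism (strain STD-dd) with Mus musculus as the target, in the maximal electroshock model, with a stated time of 2 h; on this read-out lower numbers stand for an effect already at smaller amounts and higher numbers for an effect only at larger amounts of compound. Compound 1 `CC(C)NS(=O)(=O)Cc1noc2ccc(F)cc12` gives 38 mg/kg. Compound 2 `CNS(=O)(=O)Cc1noc2ccc(Cl)cc12` gives 20 mg/kg, and compound 3 `CCNS(=O)(=O)Cc1noc2ccc(Cl)cc12` gives 21 mg/kg. Among the measured compounds shown here, the step of a 1.1-fold higher number from compound 2 to compound 3 (0.02 log units; within the scatter) is the only single change measured so far. Compound 3 holds the second highest of the three numbers; compound 2 is its nearest neighbour and compound 1 its furthest, both within the scatter.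

The next step leads to compound 4 `CC(C)NS(=O)(=O)Cc1noc2ccc(Cl)cc12`, which differs from compound 3 by methyl in place of hydrogen on a saturated chain carbon bound to a saturated chain carbon and a sulfonamide nitrogen. For the measured compounds named here, the one measured step that bears on this change is the one from compound 2 to compound 3, a methyl added on the same chain carbon, and it stayed within the scatter. Compound 1, which carries the isopropyl group but fluorine instead of chlorine, gives 38 mg/kg, against 21 mg/kg for compound 3, again within the scatter. Compound 4 is therefore expected to show a step of a 1.2-fold higher number from compound 3 to compound 4 (0.08 log units; within the scatter), not beyond the scatter. The estimate for compound 4 in this assay is 25 mg/kg, with a range from 14 mg/kg to 45 mg/kg.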

Compound 4, dose for half-maximal effect: 100 mg/kg
Compound 4: middle estimate off by 4.0-fold (0.60 log units), on the low side, and the stated range ends below it.
By their numbers in this assay, from the lowest: compounds 2, 3 and 1 (each within the scatter of the next); then compound 4.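

In this assay the methyl on the saturated chain carbon bound to a saturated chain carbon and a sulfonamide nitrogen, which turns ethyl into isopropyl, gives a 4.8-fold higher number from compound 3 to compound 4 (0.68 log units; beyond the scatter) whereas the change from methyl to ethyl on the same nitrogen gave only a 1.1-fold higher number from compound 2 to compound 3 (0.02 log units; within the scatter) and so the amine proves able to move the number beyond the scatter. Taken as a whole, isopropyl in place of methyl on a sulfonamide nitrogen gives a 5.0-fold higher number from compound 2 to compound 4 (0.70 log units; beyond the scatter) and with isopropyl in place the halogen also counts, as chloro in place of fluoro gives a 2.6-fold higher number from compound 1 to compound 4 (0.42 log units; beyond the scatter) on an aromatic carbon. Nothing at hand explains this rise.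

From the compounds shown here alone, whether the rise follows the branching or the added carbon alone stays open, and a straight propyl or a cyclopropyl on the sulfonamide nitrogen would bear on that. Also open, going by these compounds, is whether fluoro in place of chloro would matter with the ethyl or methyl amines.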